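The source may report more compounds than this note shows. Statements on the series, on what has been measured and on what is new or still open speak of the compounds shown alone.

Values in a physicochemical assay for solubility, at pH 7.4; a lower number here means a less soluble compound, a higher number a more soluble compound:
- compound 1 `Cc1cc(Cl)c(-c2cn(C)cn2)cc1NC(=O)c1ccc(OCc2ccccn2)cc1` gives 20000 nM
- compound 2 `Cc1cc(Cl)c(-c2cn(C)c(C)n2)cc1NC(=O)c1ccc(OCc2ccccn2)cc1` gives < 1000 nM, which is a limit
- compound 3 `Cc1ccc(-c2cnc(C)n2C)cc1NC(=O)c1ccc(OCc2ccccn2)cc1` gives 371000 nM

Within the data shown here, only two of these values are actual numbers, and compound 1, at 20000 nM, holds the lower one. Compound 3 gives 371000 nM, a gap beyond the scatter.

Compound 4 `Cc1cc(C)c(-c2cn(C)cn2)cc1NC(=O)c1ccc(OCc2ccccn2)cc1` carries methyl in place of chloro on an aromatic carbon, ortho to a 1-methyl-1H-imidazol-4-yl group and meta to a methyl group (methyl in place of chloro on an aromatic carbon).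

Among the measured compounds shown here, the one measured step, an at least 20-fold lower number from compound 1 to compound 2 (1.30 log units; beyond the scatter), is large and beyond the scatter, and it rests on a limit (the limit of < 1000 nM in this assay, at which 1 of the 3 values shown sits). That step puts methyl in place of hydrogen on an aromatic carbon and replaces no chloro, so it bears on the new change only indirectly. For the measured compounds named here, no measured step replaces chloro with methyl. No step beyond the scatter is therefore expected in this assay, and the expected step is a 1.3-fold higher number from compound 1 to compound 4 (0.10 log units; within the scatter). The estimate for compound 4 is 25000 nM, with an expected range from 6000 nM to 100000 nM.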

Compound 4, solubility: 8000 nM
Beside the measured number, compound 4's estimate is 3.1-fold (0.49 log units) above it, within the range that was stated.
By their numbers in this assay, from the lowest: compound 4; then compound 1; then compound 3. At a limit, below all of these: compound 2.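

Methyl in place of chloro gives a 2.5-fold lower number from compound 1 to compound 4 (0.40 log units; beyond the scatter) in this assay, so the aromatic carbon ortho to a 1-methyl-1H-imidazol-4-yl group and meta to a methyl group is not silent in this read-out. Among these compounds, this is the first measured step at that position; the only earlier step, an at least 20-fold lower number from compound 1 to compound 2 (1.30 log units; beyond the scatter), changes a different place. One heavy atom leaves and one enters, with no hydrogen-bond donors or acceptors on either side, and nothing measured here gives a cause for the step.

Open, on these data alone, is how hydrogen, fluoro, methoxy or an amine at this position would compare with chloro and methyl. Also open, as far as these compounds go, is how the change behaves alongside the added methyl of compound 2, whose < 1000 nM is a limit.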